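The compounds below may be only part of what the source reports. "The series", "measured", "known", "first", "only" and "open" are said of these compounds alone.

Compound 1 `COc1cc(C)nc2n/c(=N/C(=O)c3c(-c4ccc(Cl)cc4Cl)noc3C)sn12` gives 80.5% in a functional assay on the whole organism (strain L.) for inhibition, with Echinochloa crus-galli as the target, with a stated time of 72 h, tested at 100 mg/L; a higher number here means more inhibition of growth at the concentration tested, a lower number less inhibition of growth.
Compound 2 `COc1cc(SC)nc(NC(=S)NC(=O)c2c(-c3ccc(Cl)cc3Cl)noc2C)n1` gives 40.9% in this assay.
Compound 3 `CSc1cc(C)nc2n/c(=N/C(=O)c3c(-c4ccc(Cl)cc4Cl)noc3C)sn12` gives 75.4% in this assay.

Compound 1 stands highest of the three numbers; compound 3 lies within the scatter of it, while compound 2, with an opened-up core, sits far lower. Compound 4 `COc1cc(Cl)nc2n/c(=N/C(=O)c3c(-c4ccc(Cl)cc4Cl)noc3C)sn12` keeps the core of compound 1 and differs by chloro in place of methyl on an aromatic carbon. Going by the values given here, only one measured step bears on this: from compound 1 to compound 3, swapping the methoxy for a methylsulfanyl group, the change was a number 5.1 percentage points lower from compound 1 to compound 3 (within the scatter). Among the compounds with values here, no measured step replaces the methyl itself, so the guidance is thin. Small changes on this ring appear tolerated, and compound 4 is therefore expected to show a number 2.5 percentage points lower from compound 1 to compound 4 (within the scatter), no shift beyond the scatter. The estimate for compound 4 is 78%, with a range from 60% to 92%.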

Compound 4, percent growth inhibition at one concentration: 40.8%
The estimate for compound 4 lay 37.2 percentage points above the measured number; measured number below the stated range.
By their numbers in this assay, from the lowest: compounds 4 and 2 (each within the scatter of the next); then compounds 3 and 1 (each within the scatter of the next).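

This position is sensitive to change: in this assay, putting chloro in place of methyl, on the aromatic carbon next to the ring nitrogen, gives a number 39.7 percentage points lower from compound 1 to compound 4 (beyond the scatter). The earlier change of methoxy to methylsulfanyl gave only a number 5.1 percentage points lower from compound 1 to compound 3 (within the scatter), so small swaps on this ring are not tolerated equally at every site. Nothing available here explains the loss.

From the compounds shown here alone, it remains open whether the drop is specific to chloro or whether methyl is itself needed here. An ethyl group or an amine at this carbon could help separate these two readings.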